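The compounds below may be only part of what the source reports. "The series", "measured", "known", "first", "only" and "open" are said of these compounds alone.

The measured compounds:
compound 1 `O=C(/C(=C\c1ccc(O)cc1)SCc1ccc(Cl)cc1)c1ccc(Br)cc1`, 10000 nM
compound 2 `O=C(/C(=C\c1ccc(O)cc1)S(=O)(=O)Cc1ccc(F)cc1)c1ccc(Br)cc1`, 10000 nM
compound 3 `O=C(O)c1cc(/C=C(/Sc2ccc(Br)cc2)C(=O)c2c(F)c(F)c(F)c(F)c2F)ccc1O`, 25000 nM

All three were tested in a functional assay on DU-145 cells (Homo sapiens) for inhibition, read by trypan blue exclusion, with a stated time of 96 h; a higher number here means a weaker inhibitor of growth, a lower number a stronger inhibitor of growth. Compound 2 gives 10000 nM, level at the digits shown with compound 1, and the two together hold the lowest numbers of the three; compound 3 sits at a higher number, beyond the scatter. Compound 4 `Cc1cc(C)cc(/C=C(\C(=O)c2ccc(Br)cc2)S(=O)(=O)Cc2ccc(F)cc2)c1` differs from compound 2 in one place: 3,5-dimethylphenyl in place of 4-hydroxyphenyl on a double-bonded chain carbon bound to a double-bonded chain carbon. Within the data shown here, no pair of measured compounds shows a change of this kind, so the data offer no step to lean on. The expected step is a 1.5-fold higher number from compound 2 to compound 4 (0.18 log units; within the scatter), most likely toward a higher number but not surely beyond the scatter. Compound 4 is therefore estimated at 15000 nM, with a range from 5000 nM to 40000 nM.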

Compound 4, concentration for 50% growth inhibition: 10000 nM
Compound 4: middle estimate off by 1.5-fold (0.18 log units), on the high side; the measured number falls inside the stated range.
By their numbers in this assay, from the lowest: compounds 1, 2 and 4 (each within the scatter of the next); then compound 3.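

In this assay, 3,5-dimethylphenyl in place of 4-hydroxyphenyl on a double-bonded chain carbon bound to a double-bonded chain carbon gives no change at the digits printed from compound 2 to compound 4 (within the scatter), the first step read at this position. The entering group has no hydrogen-bond donor or acceptor, so in this pair the hydroxyl of 4-hydroxyphenyl is not required to hold this level of growth inhibition. Nothing available explains this result.

Still open, going by these compounds, is whether an amine at this position would give a step beyond the scatter. Also open, on these data alone, is whether the same swap would read alike with the other parts of the shared core altered.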